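Cytotoxicity ceiling in the series, toward compound 4

The source may report more compounds than this note shows. Statements on the series, on what has been measured and on what is new or still open speak of the compounds shown alone.

Compound 1 `CCOC(=O)CCCCCOc1cccc(CN(C(=O)c2ccc(-c3cccc(OCC(C)C)c3)cc2)C(C)C)c1` gives > 26000 nM in an ADME assay on HepG2 cells (Homo sapiens) for cytotoxicity, read by CellTiter-Glo and resazurin assay, with a stated time of 72 h (on this read-out higher numbers stand for an effect only at larger amounts of compound and lower numbers for an effect already at smaller amounts), a limit of the assay rather than a number. Compound 2 `CCOC(=O)CCCCCOc1cccc(CN(C(=O)c2ccc(-c3ccc4c(c3)OCCO4)cc2)C(C)C)c1` likewise gives only the limit > 24400 nM in this assay. Compound 3 `CCOC(=O)CCCCCOc1cccc(CN(C(=O)c2ccc(-c3cc(OC)ccc3F)cc2)C(C)C)c1` gives the limit > 26000 nM in this assay, so it stands at the same ceiling as the other two. These positions are summarised by the limit of > 26000 nM in this assay, at which 2 of the 3 values shown sit, and (the limit of > 24400 nM in this assay, at which 1 of the 3 values shown sits). The steps a step that the two limits leave unreadable from compound 1 to compound 2, a step that the two limits leave unreadable from compound 1 to compound 3 and a step that the two limits leave unreadable from compound 2 to compound 3 therefore cannot be sized. Compound 4 `CCOC(=O)CCCCCOc1cccc(CN(C(=O)c2ccc(-c3cccc(CC(=O)O)c3)cc2)C(C)C)c1` differs from compound 3 by 3-(carboxymethyl)phenyl in place of 2-fluoro-5-methoxyphenyl on an aromatic carbon. Going by the values given here, no measured step bears readably on this change, so no step beyond the scatter is expected in this assay. The expected step of a number no higher from compound 3 to compound 4 (the limit leaves the size open) is essentially none. Compound 4 is estimated at 26000 nM, within 10000 nM to 60000 nM, most likely again as a limit.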

Compound 4, half-maximal effective concentration: > 26000 nM
Compound 4 ended at the assay's limit; the forecaster's own chance of this, stated with the estimate: 85%; the middle value lies on the limit itself.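

Going by these compounds alone, compound 1, compound 2, compound 3 and compound 4 all give only limits in this assay, so no step among them can be read. Still open is whether any of these compounds shows cytotoxicity at a measurable concentration in this assay.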